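A few compounds are considered here, and "the series" means these few. Any claim that something is new, unique, unknown or untested is made for them only; others in the source may bear on it.

Compound 1, with the structure `CSc1ccc(CNc2nc(SC)nc3ncccc23)cc1`, stands lowest of the three numbers recorded in an ADME assay on BEAS-2B cells (Homo sapiens) for cytotoxicity, read by MTT assay, with a stated time of 72 h (a higher number here means a weaker inhibitor of growth, a lower number a stronger inhibitor of growth), where compound 1 gives 600 nM. The nearest of the others is compound 3, `[SeH]c1nc(NCc2ccccc2)c2ccccc2n1`, which in this assay gives 3540 nM; the furthest is compound 2, `C[Se]c1nc(N)c2ccccc2n1`, which gives 23600 nM. Both of those gaps lie beyond the scatter.

Compound 4, `CSc1nc(NCc2ccccc2)c2cccnc2n1`, differs from compound 1 only by hydrogen in place of methylsulfanyl on an aromatic carbon. For the measured compounds named here, no pair of measured compounds isolates this particular change, so there is nothing in the data to set its size. A modest step is expected, toward a higher number, and the estimate for compound 4 is 1100 nM with a range of 350 nM to 3500 nM, meaning an expected step of a 1.8-fold higher number from compound 1 to compound 4 (0.26 log units; within the scatter).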

Compound 4, concentration for 50% growth inhibition: 25900 nM
Estimate against measurement, compound 4: 24-fold (1.37 log units) below; measured number above the stated range.
By their numbers in this assay, from the lowest: compound 1; then compound 3; then compounds 2 and 4 (each within the scatter of the next).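

Replacing methylsulfanyl with hydrogen on an aromatic carbon, para to a large group, gives a 43-fold higher number from compound 1 to compound 4 (1.64 log units; beyond the scatter) in this assay. This is the first single change that can be read among these compounds, and it shows that this place has a large bearing on the number in this assay. Nothing at hand accounts for the size of the step.

The compounds shown leave open whether methoxy, chlorine or a longer alkylsulfanyl chain at this place would give a number nearer that of compound 1. They also leave open whether the step would recur on another core.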